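Leaving the acetamido group: from compound 2 to compound 4

The source may hold more compounds than are shown below. What is called first, only, known or untested is meant among the compounds shown, and "the series" means these compounds.

Compound 1 `COc1ccccc1CN1CCC=C(CCC(=O)NO)C1=O`: > 10000 nM (a limit)
Compound 2 `CC(=O)Nc1ccc(CN2CCC=C(CCC(=O)NO)C2=O)cc1`: > 10000 nM (a limit)
Compound 3 `Cc1ccc(S(=O)(=O)Nc2ccc(CN3CCC=C(CCC(=O)NO)C3=O)cc2)cc1`: 1800 nM

In a functional assay on PC-3 cells (Homo sapiens) for inhibition, read by sulforhodamine B assay (a lower number here means a stronger inhibitor of growth, a higher number a weaker inhibitor of growth), compound 2 gives > 10000 nM, which is a limit and not a number. Compound 1 and compound 2 both stand at the limit of > 10000 nM in this assay, at which 2 of the 3 values shown sit.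

Compound 4 `O=C(CCC1=CCCN(Cc2ccc(Br)cc2)C1=O)NO` carries bromo in place of acetamido on an aromatic carbon, para to a large group (bromo in place of acetamido on an aromatic carbon). Going by the values given here, only one measured step bears on this change: an at least 5.5-fold lower number from compound 2 to compound 3 (0.74 log units; beyond the scatter). That step replaces the acetyl on the nitrogen of the same group, so it shows that a change at this place can lower the number in this assay. Among the compounds with values here, it is a different change, however, and no measurement yet covers bromo. A modest step towards a lower number is therefore expected, with a real chance that compound 4 also ends at a limit. The expected step is an at least 1.6-fold lower number from compound 2 to compound 4 (0.22 log units; that floor lies within the scatter). For compound 4 the estimated value is 6000 nM, with an expected range from 2500 nM to 15000 nM.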

Compound 4, concentration for 50% growth inhibition: 3150 nM
The estimate for compound 4 lay 1.9-fold (0.28 log units) above the measured number, and the stated range covers the measured number.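

In this assay, bromo in place of acetamido on the aromatic carbon para to a large group gives an at least 3.1-fold lower number from compound 2 to compound 4 (0.50 log units; beyond the scatter). Going by these compounds alone, until now, compound 3 was the only compound with a measured number, and it keeps a nitrogen on the ring; compound 4 shows that a measured number can be reached here with neither that nitrogen nor a sulfonyl group, only a single bromine atom. Compound 2 stands at a limit and not at a number, so the step gives only a floor on its size: the limit of > 10000 nM in this assay, at which 2 of the 4 values shown sit.

The compounds shown do not separate what bromine itself contributes from the mere loss of acetamido. From the compounds shown here alone, whether chloro, fluoro or a free amine on the same carbon would behave like bromo remains open.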